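Removing a Methoxy Group: A Step Expected to Stay Small

The source may hold more compounds than are shown below. What is called first, only, known or untested is meant among the compounds shown, and "the series" means these compounds.

Three compounds were tested in a functional assay on MCF7 cells (Homo sapiens) for cytotoxicity, read by sulforhodamine B assay, with a stated time of 48 h, tested at 0.1 uM; on this read-out higher numbers stand for a weaker effect at the one concentration tested and lower numbers for a stronger effect. Compound 1 `COc1cc(-c2cc(/C=C/C(=O)c3ccc(N)cc3)[nH]n2)cc(OC)c1OC` gives 91%; compound 2 `COc1ccc(C(=O)/C=C/c2cc(-c3cc(OC)c(OC)c(OC)c3)n[nH]2)cc1OC` gives 91%; compound 3 `COc1ccc(C(=O)/C=C/c2cc(-c3cc(OC)c(OC)c(OC)c3)n[nH]2)cc1` gives 93%. Compound 1 and compound 2 differ in their cores by 4-aminophenyl in place of 3,4-dimethoxyphenyl on a carbonyl carbon. From compound 2 to compound 3 the change is hydrogen in place of methoxy on an aromatic carbon, and a number 2 percentage points higher from compound 2 to compound 3 (within the scatter). Compound 4 `COc1ccc(-c2cc(/C=C/C(=O)c3ccc(N)cc3)[nH]n2)cc1OC` remains to be measured. It arises from compound 1 by the same kind of change, (hydrogen in place of methoxy on an aromatic carbon); here the place is also meta to a methoxy group (2 heavy atoms), which the place in compound 2 is not. The step is expected to be small, a number 1 percentage points higher from compound 1 to compound 4 (within the scatter), because a number 2 percentage points higher from compound 2 to compound 3 (within the scatter) and because compound 1 stands at 91%. Compound 4 is therefore estimated at 92%, between 82% and 100%.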

Compound 4, a percentage reported as activity, at one concentration (the size of the read-out at that concentration, not a potency): 89%
Beside the measured number, compound 4's estimate is 3 percentage points above it; measured number inside the range.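

In this assay, hydrogen in place of methoxy on the core of compound 1 gives a number 2 percentage points lower from compound 1 to compound 4 (within the scatter) and, set beside the same change on the other core, the two steps do not differ: the same change on two cores in this assay, a number 2 percentage points higher (within the scatter) from compound 2 to compound 3 and a number 2 percentage points lower (within the scatter) from compound 1 to compound 4, 4 percentage points apart, within the scatter of two such steps. In this pair of cores the change therefore carries over as a step that stays within the scatter on both. This does not show that the change is without effect on these cores, since one concentration gives no potency and a difference at other concentrations would not appear here.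

The compounds shown leave open how a hydroxy group, a fluorine atom or an ethoxy group would read in place of this methoxy group. They also leave open how an acetamide or a dimethylamino group would read in place of the amino group of compound 1.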